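From phenyl to isopropyl in a small growth-inhibitor set

The source may hold more compounds than are shown below. What is called first, only, known or untested is meant among the compounds shown, and "the series" means these compounds.

In a functional assay on HCT-116 cells (Homo sapiens) for inhibition, read by fluorescence, with a stated time of 48 h (a higher number here means a weaker inhibitor of growth, a lower number a stronger inhibitor of growth), compound 1 `CC(C)(COC(=O)[C@@H](N)c1ccccc1)COC1(c2ccc(Cl)cc2)c2ccccc2C(=O)N1Cc1ccccc1` gives 15000 nM. Compound 2 `N[C@H](C(=O)OCCCOC1(c2ccc(Cl)cc2)c2ccccc2C(=O)N1Cc1ccc(Cl)cc1)c1ccccc1` gives 12000 nM, and these two numbers lie within the usual scatter of each other, so they count as the same result. Compound 3 `O=C1c2ccccc2C(OCCCO)(c2ccc(Cl)cc2)N1Cc1ccccc1` gives 79000 nM, a number beyond the scatter from that of compound 1, which means weaker growth inhibition. Compound 1 therefore stands level with compound 2, at the stronger end of these three results.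

The next molecule, compound 4 `CC(C)[C@H](N)C(=O)OCC(C)(C)COC1(c2ccc(Cl)cc2)c2ccccc2C(=O)N1Cc1ccccc1`, alters compound 1 in one place: isopropyl in place of phenyl on a saturated chain carbon bound to an amine nitrogen and a carbonyl carbon. Among the measured compounds shown here, no measured pair here shows this swap, so the data cannot give its size directly. The starting point for a forecast is simply compound 1 at 15000 nM. In this assay, no step beyond the scatter is expected, with any drift more likely toward a slightly higher number. The expected change is a 1.3-fold higher number from compound 1 to compound 4 (0.12 log units; within the scatter). For compound 4, the estimated value is 20000 nM, with an expected range from 7000 nM to 50000 nM.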

Compound 4, concentration for 50% growth inhibition: 20000 nM
For compound 4 middle estimate and measured number coincide at the digits printed; the measured number falls inside the stated range.
By their numbers in this assay, from the lowest: compounds 2, 1 and 4 (each within the scatter of the next); then compound 3.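

In this assay putting isopropyl in place of phenyl on a saturated chain carbon bound to an amine nitrogen and a carbonyl carbon gives a 1.3-fold higher number from compound 1 to compound 4 (0.12 log units; within the scatter) and so counts as no real change. This position therefore accepts a group of 3 heavy atoms with no ring as well as one with 6 heavy atoms in a six-membered aromatic ring, so in this one pair the aromatic ring is not needed to hold the reading. The wider change, 1-((((1-amino-2-methylpropyl)carbonyl)oxy)methyl)-1-methylethyl in place of 2-hydroxyethyl on a saturated chain carbon bound to an oxygen on a saturated carbon, gives a 4.0-fold lower number from compound 3 to compound 4 (0.60 log units; beyond the scatter) and shows that the isopropyl version still reads as a stronger inhibitor of growth than compound 3, by a modest step.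

On these data alone, whether a smaller group such as methyl, or a longer chain such as n-butyl, would hold the same reading at this position remains open. No measurement at hand bears on this result.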